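This account rests on a few compounds, and the source may have more. Where it says the series, first, only, none or still open, it means among the compounds named here.

Three compounds of the series carry measurements in an ADME assay on microsomes from liver (Homo sapiens) for metabolic stability, read by LC-MS, using NADPH, with stated times of 5 min and 30 min, tested at 1 uM; a higher number here means faster removal of the compound, a lower number slower removal. Compound 1 `O=C1CCCN1c1cnc(NCc2c(F)ccc3c2CCO3)c2cn[nH]c(=O)c12` gives 23 mL.min-1.g-1, compound 2 `CC1(C)CC(=O)N(c2cnc(NCc3c(F)ccc4c3CCO4)n3cnnc23)C1` gives 16 mL.min-1.g-1, and compound 3 `Cc1ncccc1-c1cnc(NCc2c(F)ccc3c2CCO3)c2ncc(=O)[nH]c12` gives 21 mL.min-1.g-1. Compound 1 has the highest of the three numbers, but its gaps to compound 3 and to compound 2 both lie within the usual scatter, so the three are not separated. Compound 4 `Cc1ncccc1-c1cnc(NCc2c(F)ccc3c2CCO3)c2cn[nH]c(=O)c12` is not yet measured in this assay. It differs from compound 1 in one place: 2-methylpyridin-3-yl in place of 2-oxopyrrolidin-1-yl on an aromatic carbon. Within the data shown here, no step between measured compounds isolates this change. Compound 3 carries the same 2-methylpyridin-3-yl on a different core and gives 21 mL.min-1.g-1, close to compound 1. Compound 4 is therefore expected to show a step of a 1.0-fold lower number from compound 1 to compound 4 (0.02 log units; within the scatter) that stays within the scatter. The estimate for compound 4 in this assay is 22 mL.min-1.g-1, with a range from 11 mL.min-1.g-1 to 44 mL.min-1.g-1.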

Compound 4, intrinsic clearance in microsomes: 41 mL.min-1.g-1
Estimate against measurement, compound 4: 1.9-fold (0.27 log units) below, within the range that was stated.
By their numbers in this assay, from the lowest: compounds 2, 3, 1 and 4 (each within the scatter of the next, the first and the last beyond it).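

In this assay, among these compounds, 2-methylpyridin-3-yl in place of 2-oxopyrrolidin-1-yl on the shared core gives a 1.8-fold higher number from compound 1 to compound 4 (0.25 log units; within the scatter), the first step in this set that isolates this position. A six-membered aromatic ring and a five-membered non-aromatic ring are therefore not separated here on the core of compound 1. No measurement at hand bears on the reason for this step.

As far as these compounds go, whether a dimethylamino group or a carboxylic acid at this position would also stay within the scatter of compound 1 remains open.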